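Fluoro Added to an Alkyne-Linked Thiazole Core

This account rests on a few compounds, and the source may have more. Where it says the series, first, only, none or still open, it means among the compounds named here.

Compound 1 `COc1ccccc1C#Cc1nc2c(s1)C(=O)NCC2` gives > 10000 nM in an assay on HEK293 cells for negative allosteric modulation of metabotropic glutamate receptor 5 (Homo sapiens), read by FLIPR, with a stated time of 1 h; on this read-out higher numbers stand for weaker inhibition and lower numbers for stronger inhibition. Compound 2 `CN1CCc2nc(C#Cc3ccccc3)sc2C1` gives > 10000 nM in the same assay.

Both values are limits of this assay, not measured numbers. For compound 2 the value is only a limit, and it sits where the limit of > 10000 nM in this assay, at which 2 of the 2 values shown sit, applies. Compound 3 `CN1CCc2nc(C#Cc3cccc(F)c3)sc2C1` has not been measured; it differs from compound 2 by fluoro in place of hydrogen on an aromatic carbon. Within the data shown here, with no measured step of this kind to lean on, only a small change is expected, none beyond the usual scatter, so compound 3 is expected to stay near the limit, with a step that the limit leaves unreadable from compound 2 to compound 3. The estimate for compound 3 in this assay is 12000 nM, between 3000 nM and 40000 nM.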

Compound 3, half-maximal inhibitory concentration: > 10000 nM
Compound 3: no number, only a limit; the forecaster's own chance of this, stated with the estimate: 75%; the middle value does not contradict the limit.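

Compound 2 and compound 3 both sit at the limit of this assay, so the step from hydrogen to fluoro between them cannot be read. The compounds shown leave open how strongly either compound actually inhibits the receptor.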